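The source may report more compounds than this note shows. Statements on the series, on what has been measured and on what is new or still open speak of the compounds shown alone.

Compound 1 `NC(=O)c1cc(Cl)ccc1NC(=O)COc1ccccc1` gives 5900 nM
Compound 2 `NC(=O)c1cc(I)ccc1NC(=O)COc1ccccc1` gives 657 nM

In a functional assay on NCI-H23 cells (Homo sapiens) for inhibition (on this read-out lower numbers stand for stronger inhibition of growth and higher numbers for weaker inhibition of growth), compound 2 stands at 657 nM as the lower of the two numbers. Compound 3 `COc1ccc(NC(=O)COc2ccccc2)c(C(N)=O)c1` has methoxy in place of iodo on an aromatic carbon. For the measured compounds named here, only one measured step bears on this carbon, iodo in place of chloro (a 9.0-fold lower number from compound 1 to compound 2 (0.95 log units; beyond the scatter)), and no methoxy compound has been measured. On that step, a higher number of roughly the same size is expected in this assay, though with wide uncertainty. The expected step is (a 6.1-fold higher number from compound 2 to compound 3 (0.78 log units; beyond the scatter)). Compound 3 is estimated at 4000 nM (expected range 1200 nM to 15000 nM).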

Compound 3, concentration for 50% growth inhibition: 1380 nM
The estimate for compound 3 lay 2.9-fold (0.46 log units) above the measured number, and the stated range covers the measured number.
By their numbers in this assay, from the lowest: compound 2; then compound 3; then compound 1.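

In this assay, this carbon is not restricted to halogens: methoxy in place of iodo gives a 2.1-fold higher number from compound 2 to compound 3 (0.32 log units; beyond the scatter), while methoxy in place of chloro gives a 4.3-fold lower number from compound 1 to compound 3 (0.63 log units; beyond the scatter). The methoxy compound therefore falls between the two halogen compounds, with both steps beyond the usual scatter, so the order does not simply follow a series of halogens. No evidence is available to explain this order. As far as these compounds go, whether an amine, a carboxylic acid or an ethoxy group on this carbon would fall within the same span remains open.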